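This account rests on a few compounds, and the source may have more. Where it says the series, first, only, none or still open, it means among the compounds named here.

Compound 1 `COc1cc(-c2cc(/C=C/C(=O)c3ccc(N)cc3)[nH]n2)cc(OC)c1OC`: -45%
Compound 2 `COc1cc(-c2cc(/C=C/C(=O)c3ccc(Cl)c(Cl)c3)[nH]n2)cc(OC)c1OC`: 56%
Compound 3 `COc1ccc(C(=O)/C=C/c2cc(-c3cc(OC)c(OC)c(OC)c3)n[nH]2)cc1`: -69%

These numbers come from a functional assay on SN12C cells (Homo sapiens) for cytotoxicity, read by sulforhodamine B assay, with a stated time of 48 h, tested at 10 uM; a lower number here means a stronger effect, a higher number a weaker effect of the compound at the concentration tested. Compound 3 stands lowest of the three: the step of a number 24 percentage points lower from compound 1 to compound 3 (beyond the scatter) is modest, while a number 125 percentage points lower from compound 2 to compound 3 (beyond the scatter) is large. Compound 4 `COc1cc(-c2cc(/C=C/C(=O)c3ccc(F)c(F)c3)[nH]n2)cc(OC)c1OC` differs from compound 3 in one place: 3,4-difluorophenyl in place of 4-methoxyphenyl on a carbonyl carbon. Most relevant is the step of a number 125 percentage points lower from compound 2 to compound 3 (beyond the scatter), where a 3,4-dichlorophenyl ring gave way to the 4-methoxyphenyl ring, the reverse of the present change; the step of a number 101 percentage points higher from compound 1 to compound 2 (beyond the scatter) likewise rose strongly when 3,4-dichlorophenyl entered. A large rise is therefore expected for compound 4, a number 89 percentage points higher from compound 3 to compound 4 (beyond the scatter), though how closely 3,4-difluorophenyl follows 3,4-dichlorophenyl cannot be read from these three compounds. Compound 4 is estimated at 20%, within -40% to 70%.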

Compound 4, a percentage reported as activity, at one concentration (the size of the read-out at that concentration, not a potency): 15%
Compound 4: middle estimate off by 5 percentage points, on the high side; low and high end bracket the measured number.
By their numbers in this assay, from the lowest: compound 3; then compound 1; then compound 4; then compound 2.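

In this assay, swapping one halogen for another on this ring matters: a number 41 percentage points lower from compound 2 to compound 4 (beyond the scatter) shows that 3,4-difluorophenyl does not simply reproduce 3,4-dichlorophenyl. Even so, the fluorinated ring stays on the weaker side, as a number 84 percentage points higher from compound 3 to compound 4 (beyond the scatter) and a number 60 percentage points higher from compound 1 to compound 4 (beyond the scatter) show, so both halogen-bearing rings sit above the 4-methoxyphenyl and 4-aminophenyl rings. Nothing measured here explains these differences. From the compounds shown here alone, whether a 4-hydroxyphenyl or an unsubstituted phenyl ring on the carbonyl carbon would group with the 4-methoxyphenyl and 4-aminophenyl rings or with the halogen-bearing rings remains open.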